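A few compounds are considered here, and "the series" means these few. Any claim that something is new, unique, unknown or untested is made for them only; others in the source may bear on it.

Compound 1 `CC(C)C(Cc1nnc[nH]1)c1ccc(-c2ccc3cccc(F)c3c2)[nH]c1=O` was tested in an ADME assay on microsomes from liver (Homo sapiens) for metabolic stability (on this read-out lower numbers stand for a shorter-lived compound and higher numbers for a longer-lived compound), where compound 1 gives 0.307 h. Compound 3 `CCC(CC)(c1nnc[nH]1)c1ccc(-c2ccc3cccc(F)c3c2)[nH]c1=O` shares the same core and gives 1.19 h in this assay, a higher number by a margin beyond the usual scatter, so compound 1 stands lowest of the two plain numbers. Compound 2 `CCn1ncc2c(F)cc(-c3ccc(C(CC)(CC)c4nnc(C)[nH]4)c(=O)[nH]3)cc21` reaches only a limit of this assay, > 3 h, which is the limit at which (the limit of > 3 h in this assay, at which 1 of the 3 values shown sits).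

Compound 4 `CC(C)C(c1noc(=O)[nH]1)c1ccc(-c2ccc3cccc(F)c3c2)[nH]c1=O` has not yet been measured. It differs from compound 1 by a group of 6 heavy atoms (2 carbon, 2 nitrogen, 2 oxygen; one five-membered aromatic ring with 3 hetero atoms) in place of a group of 6 heavy atoms (3 carbon, 3 nitrogen; one five-membered aromatic ring with 3 hetero atoms), on a saturated chain carbon bound to an aromatic carbon and a saturated chain carbon. Among the compounds with values here, no measured pair shows such a change, so the step is expected to stay within the scatter: a 1.1-fold higher number from compound 1 to compound 4 (0.06 log units; within the scatter). Compound 4 is therefore estimated at 0.35 h in this assay, with a range from 0.15 h to 0.9 h.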

Compound 4, half-life: > 3 h
Compound 4: a limit, no number; the forecaster's own chance of this, stated with the estimate: 5%; middle value at least 8.5-fold (0.93 log units) away from the limit.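

On a saturated chain carbon bound to an aromatic carbon and a saturated chain carbon, replacing (4H-1,2,4-triazol-3-yl)methyl with a ring of 2 carbon, 2 nitrogen and 2 oxygen atoms gives an at least 9.7-fold higher number from compound 1 to compound 4 (0.98 log units; beyond the scatter) in this assay. Within the data shown here, this is the first single-place change here, and it shows that the group at this position can strongly shift the half-life. The step is only a lower bound because compound 4 sits at a limit: the limit of > 3 h in this assay, at which 2 of the 4 values shown sit.

From the compounds shown here alone, whether the new ring or the loss of the methyl link drives the step remains open. So does the effect of a carboxylic acid or an amine at this position.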